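Cyclopropyl in Place of 3-Fluorobenzyl on the Amino Nitrogen

The source may report more compounds than this note shows. Statements on the series, on what has been measured and on what is new or still open speak of the compounds shown alone.

Of the compounds shown here, three sharing one core have been measured in a functional assay on CHO cells for agonist activity at adenosine receptor A3 (Homo sapiens), read by scintillation counting and cAMP accumulation, with stated times of 45 min and 15 min, in the presence of a further agent that is not named here; on this read-out higher numbers stand for an effect only at larger amounts of compound and lower numbers for an effect already at smaller amounts. Compound 1 `CCCCC#Cc1nc(NC2CCCC2)c2ncn([C@H]3[C@H](O)[C@H](O)[C@@H]4C[C@@H]43)c2n1` gives 27.1 nM, compound 2 `CCCCC#Cc1nc(NC)c2ncn([C@H]3[C@H](O)[C@H](O)[C@@H]4C[C@@H]43)c2n1` gives 45.8 nM, and compound 3 `CCCCC#Cc1nc(NCc2cccc(F)c2)c2ncn([C@H]3[C@H](O)[C@H](O)[C@@H]4C[C@@H]43)c2n1` gives 18.9 nM. Compound 3 holds the lowest number of the three, but the difference a 1.4-fold lower number from compound 1 to compound 3 (0.16 log units; within the scatter) lies within the scatter, so only the difference a 2.4-fold lower number from compound 2 to compound 3 (0.38 log units; beyond the scatter) separates it clearly from another compound.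

Compound 4 `CCCCC#Cc1nc(NC2CC2)c2ncn([C@H]3[C@H](O)[C@H](O)[C@@H]4C[C@@H]43)c2n1` differs from compound 3 by cyclopropyl in place of 3-fluorobenzyl on a nitrogen on an aromatic ring. Among the compounds with values here, two measured steps bear on this change: replacing cyclopentyl by 3-fluorobenzyl gave a 1.4-fold lower number from compound 1 to compound 3 (0.16 log units; within the scatter), and replacing methyl by 3-fluorobenzyl gave a 2.4-fold lower number from compound 2 to compound 3 (0.38 log units; beyond the scatter). Cyclopropyl is smaller than cyclopentyl yet larger than methyl, so the expected number for compound 4 falls between those of compound 1 and compound 2, a step of a 1.7-fold higher number from compound 3 to compound 4 (0.23 log units; within the scatter) in this assay, most likely within the scatter. Compound 4 is therefore estimated at 32 nM, with a range from 16 nM to 64 nM.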

Compound 4, half-maximal effective concentration: 19.8 nM
Beside the measured number, compound 4's estimate is 1.6-fold (0.21 log units) above it; measured number inside the range.
By their numbers in this assay, from the lowest: compounds 3, 4, 1 and 2 (each within the scatter of the next, the first and the last beyond it).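

In this assay, the step of a 1.0-fold higher number from compound 3 to compound 4 (0.02 log units; within the scatter) shows that at this nitrogen on an aromatic ring, cyclopropyl cannot be told apart from 3-fluorobenzyl, so removing the six-membered aromatic ring and the fluorine leaves the number unchanged within the scatter. Cyclopropyl also stays within the scatter of cyclopentyl, at a 1.4-fold lower number from compound 1 to compound 4 (0.14 log units; within the scatter), and only its step from methyl, a 2.3-fold lower number from compound 2 to compound 4 (0.36 log units; beyond the scatter), passes the scatter, modestly, so a small carbocycle here does as well as the larger groups shown. No measurement shown here explains why these groups give such similar numbers.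

The compounds shown leave open whether a substituent on this nitrogen carrying an amine or a carboxylic acid would move the number clearly away from this narrow band. They also leave open how a plain amino group, with hydrogen in place of methyl, would compare with compound 2.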